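The source may hold more compounds than are shown below. What is called first, only, known or untested is meant among the compounds shown, and "the series" means these compounds.

Compound 1 `COc1cc(C)ccc1S(=O)(=O)N1CCC(N2CCC(C)CC2)CC1` reaches only a limit in an ADME assay on HCT-116 cells (Homo sapiens) for cytotoxicity, read by CellTiter-Glo, with a stated time of 72 h (a lower number here means a stronger inhibitor, a higher number a weaker inhibitor), namely > 5000 nM. Compound 2 `CC(=O)Nc1ccc(S(=O)(=O)N2CCC(N3CCC(C)CC3)CC2)c2ccccc12` likewise gives a limit, > 10000 nM. Compound 3 `CC1CCN(C2CCN(S(=O)(=O)c3ccccc3-c3ccccc3)CC2)CC1` also stops at a limit, > 5000 nM.

Compound 2 thus stands at a limit of this assay rather than at a number, as do the two other results shown. Compound 2 sits at the limit of > 10000 nM in this assay, at which 1 of the 3 values shown sits. The other two values sit at the limit of > 5000 nM in this assay, at which 2 of the 3 values shown sit. From compound 2 to compound 4 `CC1CCN(C2CCN(S(=O)(=O)c3cccc4ccccc34)CC2)CC1` the change is hydrogen in place of acetamido on an aromatic carbon. Within the data shown here, no measured step between two compounds is at hand, and all three results are limits, so no shift beyond the scatter is expected in either direction. Compound 4 is therefore expected to remain at a limit, estimated at 20000 nM with a range from 5000 nM to 80000 nM. This means an expected step that the limit leaves unreadable from compound 2 to compound 4.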

Compound 4, half-maximal inhibitory concentration: > 10000 nM
Compound 4 gave a limit, no number (the forecaster's own chance of this, stated with the estimate: 85%); the middle value lies beyond the limit too.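

Among these compounds, compound 4 also stops at a limit in this assay, > 10000 nM, as compound 2 does, so no step between these two compounds can be read. All four results are limits, which leaves open how strongly any of these compounds acts in this assay.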